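Anilino in place of thiophen-3-yl: expected cell tolerance

This account rests on a few compounds, and the source may have more. Where it says the series, first, only, none or still open, it means among the compounds named here.

Three compounds share one core and differ only in the group on the carbonyl carbon. In an ADME assay on Li23 cells (Homo sapiens) for cytotoxicity, read by WST assay (a lower number here means that less compound is tolerated, a higher number that more compound is tolerated), compound 1 `Cc1ccc(C(=O)N(C)c2ccc(C(O)(C(F)(F)F)C(F)(F)F)cc2)cc1` gives 26000 nM and compound 3 `CN(C(=O)c1ccsc1)c1ccc(C(O)(C(F)(F)F)C(F)(F)F)cc1` gives 44000 nM; compound 3 stands highest of the two plain numbers, with compound 1 nearest, and the gap a 1.7-fold higher number from compound 1 to compound 3 (0.23 log units; within the scatter) is within the scatter. For compound 2 `CN(C(=O)c1ccccn1)c1ccc(C(O)(C(F)(F)F)C(F)(F)F)cc1` this assay returns only a limit, > 100000 nM. Compound 4 `CN(C(=O)Nc1ccccc1)c1ccc(C(O)(C(F)(F)F)C(F)(F)F)cc1` differs from compound 3 in one place: anilino in place of thiophen-3-yl on a carbonyl carbon. Within the data shown here, no measured step makes this exact change; the nearest, an at least 2.2-fold lower number from compound 2 to compound 3 (0.35 log units; beyond the scatter) and an at least 3.8-fold higher number from compound 1 to compound 2 (0.58 log units; beyond the scatter), show that swapping the ring at this position shifts the number by a modest amount at most. The expected step is a 1.1-fold higher number from compound 3 to compound 4 (0.06 log units; within the scatter). Compound 4 is expected at 50000 nM, within 20000 nM to 150000 nM.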

Compound 4, half-maximal cytotoxic concentration: > 20000 nM
Compound 4 was reported as a limit (the forecaster's own chance of this, stated with the estimate: 30%); the middle value does not contradict the limit.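

Compound 4 is reported only as a limit, and the steps to it from compound 1, compound 2 and compound 3 cannot be read. Going by these compounds, whether anilino in place of thiophen-3-yl shifts the number in this assay remains open.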